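The source may hold more compounds than are shown below. What is called first, only, known or untested is meant among the compounds shown, and "the series" means these compounds.

Working notes on the series. Three compounds sharing one core have been run in a functional assay on Right cardiac atrium for agonist activity at histamine H2 receptor (Cavia porcellus), with a stated time of 30 min, in the presence of a further agent that is not named here; on this read-out lower numbers stand for an effect already at smaller amounts and higher numbers for an effect only at larger amounts of compound. Compound 2 `CCCCCNC(=O)/N=C(\N)NCCCc1sc(N)nc1C` gives 5.75 nM in this assay, the lowest of the three numbers shown. Compound 1 `Cc1nc(N)sc1CCCN/C(N)=N/C(=O)NC(C)c1cccc(F)c1` gives 26.3 nM in this assay, a step beyond the scatter above compound 2. Compound 3 `Cc1nc(N)sc1CCCN/C(N)=N/C(=O)NC(c1ccccc1)c1ccccc1` gives 39.8 nM in this assay, further still above compound 2 and likewise beyond the scatter. Compound 2 thus stands apart from the other two; compound 1 and compound 3 lie within the scatter of each other, so no order between them is claimed.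

Compound 4 `Cc1nc(N)sc1CCCN/C(N)=N/C(=O)NC(C)c1ccco1` has not been measured in this assay. Relative to compound 2 the change is 1-(furan-2-yl)ethyl in place of pentyl on an amide-type nitrogen. Among the measured compounds shown here, no step between two measured compounds matches this change exactly, so the expectation rests on the spread of the three values alone: compound 2 with its pentyl chain gives 5.75 nM, while both compounds carrying a larger group on the same nitrogen sit higher. The expected direction for compound 4 is therefore toward a higher number, with a step from compound 2 to compound 4 of a 3.5-fold higher number from compound 2 to compound 4 (0.54 log units; beyond the scatter) expected, beyond the scatter. Compound 4 is estimated to give 20 nM in this assay, within a range of 7 nM to 55 nM.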

Compound 4, half-maximal effective concentration: 9.77 nM
The estimate for compound 4 lay 2.0-fold (0.31 log units) above the measured number; the measured number falls inside the stated range.
By their numbers in this assay, from the lowest: compounds 2 and 4 (each within the scatter of the next); then compounds 1 and 3 (each within the scatter of the next).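

Placing 1-(furan-2-yl)ethyl in place of pentyl on the amide-type nitrogen in this assay gives a step that stays within the scatter, a 1.7-fold higher number from compound 2 to compound 4 (0.23 log units; within the scatter), so on this nitrogen a group carrying a five-membered aromatic ring can read the same as the open pentyl chain. Among the compounds shown here, the ring held on the saturated chain carbon bound to the amide-type nitrogen also counts for the read-out: furan-2-yl in place of 3-fluorophenyl gives a 2.7-fold lower number from compound 1 to compound 4 (0.43 log units; beyond the scatter), the first step that isolates a change of that ring alone. Nothing among the data shown accounts for either step.

On these data alone, it remains open whether the step between the two rings follows from the ring type or from the fluorine, which a plain phenyl or a thiophen-2-yl on the same carbon would help to separate. As far as these compounds go, how far the amide-type nitrogen tolerates other groups also remains open, for example a longer chain such as heptyl or a chain ending in an amine or a carboxylic acid.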